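A Methyl Added Where a Methyl Was Added Before

The compounds below may be only part of what the source reports. "The series", "measured", "known", "first", "only" and "open" are said of these compounds alone.

Compound 1 `O=C(COc1ccc(Cl)cc1)Nc1nc(-c2ccc(Br)cc2)cs1` and compound 2 `Cc1cc(OCC(=O)Nc2nc(-c3ccc(Br)cc3)cs2)ccc1Cl` share one core. In a functional assay on A549 cells (Homo sapiens) for cytotoxicity, read by MTT assay, with a stated time of 48 h (on this read-out higher numbers stand for weaker inhibition and lower numbers for stronger inhibition), compound 1 gives 46100 nM, and compound 2 gives 52100 nM. The change between them is methyl in place of hydrogen on an aromatic carbon, and it made a step of a 1.1-fold higher number from compound 1 to compound 2 (0.05 log units; within the scatter). Compound 3 `O=C(COc1ccccc1)Nc1nc(-c2ccc(Cl)cc2)cs1` rests on another core; the difference between the two cores is not broken down here. In this assay compound 3 gives 42900 nM. Compound 4 `Cc1ccccc1OCC(=O)Nc1nc(-c2ccc(Cl)cc2)cs1` has not yet been measured and differs from compound 3 by methyl in place of hydrogen on an aromatic carbon. Among the measured compounds shown here, this is the same kind of change as the one from compound 1 to compound 2, but the surroundings differ: in compound 2 the methyl is ortho to a chloro group and meta to a large group, while in compound 4 it is ortho to a large group. A small step from compound 3 to compound 4 is expected, because the earlier step of a 1.1-fold higher number from compound 1 to compound 2 (0.05 log units; within the scatter) stayed within the scatter. Compound 4 is expected to give 46000 nM in this assay. That would be a step of a 1.1-fold higher number from compound 3 to compound 4 (0.03 log units; within the scatter), expected to fall between 25000 nM and 85000 nM.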

Compound 4, half-maximal inhibitory concentration: 64900 nM
Compound 4: middle estimate off by 1.4-fold (0.15 log units), on the low side, within the range that was stated.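

In this assay the new step is a 1.5-fold higher number from compound 3 to compound 4 (0.18 log units; within the scatter), which, like the earlier step, stays within the usual scatter of repeated measurements. Set side by side, the two steps agree: the same change on two cores in this assay, a 1.1-fold higher number (0.05 log units; within the scatter) from compound 1 to compound 2 and a 1.5-fold higher number (0.18 log units; within the scatter) from compound 3 to compound 4, 1.3-fold (0.13 log units) apart, within the scatter of two such steps. This shows that on these two cores, swapping a hydrogen on an aromatic carbon for a methyl gave no step that can be told apart from the scatter, and this holds for compound 4 with its methyl ortho to a large group, but two pairs cannot show that the same would hold on any other core, and they say nothing about why the steps are this small.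

What the compounds shown leave open is whether a different group on this ring would give a step beyond the scatter, such as a methoxy group, an amine or a carboxylic acid in place of the methyl. Going by these compounds, whether a longer chain such as ethyl would behave as methyl does also remains open.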